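Removing the sulfanyl arm from the weakest of three analogues

The compounds below may be only part of what the source reports. "The series", "measured", "known", "first", "only" and "open" are said of these compounds alone.

Measured compounds:
- compound 1 `Cc1cc(Nc2cc(-c3ccccc3)[nH]n2)n2nc(SCC3CCCCC3)nc2n1`: 12600 nM
- compound 2 `Cc1cc(Nc2cc(C(C)(C)C)[nH]n2)n2nc(SCc3ccc(Br)cc3)nc2n1`: 5620 nM
- compound 3 `Cc1cc(Nc2ccn(Cc3nc(C)c4ccccc4n3)n2)n2nc(SCc3ccc(Br)cc3)nc2n1`: 960 nM

Of the compounds shown here, three sharing a fused core have been tested in a functional assay on MGC-803 cells (Homo sapiens) for inhibition, read by MTT assay, with a stated time of 72 h; a lower number here means a stronger inhibitor, a higher number a weaker inhibitor. Compound 1 gives 12600 nM in this assay, the highest number of the three. Compound 2 is nearer to it, with 5620 nM, a gap that lies beyond the usual scatter. Compound 3 stands furthest away, with 960 nM, and is the strongest inhibitor of the set. No two of these compounds differ in one place only, so none of these gaps can be tied to a single structural change.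

Compound 4 `Cc1cc(Nc2cc(-c3ccccc3)[nH]n2)n2ncnc2n1` has not yet been measured. It differs from compound 1 in one place: hydrogen in place of (cyclohexylmethyl)sulfanyl on an aromatic carbon. The (cyclohexylmethyl)sulfanyl group is lost and nothing takes its place but a hydrogen atom.

Since no single-point step between measured compounds is available, the direction of this change cannot be read from the numbers shown. Losing a group of eight heavy atoms is, however, expected to move the number upward, so the step of a 2.2-fold higher number from compound 1 to compound 4 (0.35 log units; beyond the scatter) is estimated to go beyond the scatter toward weaker inhibition. Compound 4 is therefore expected to give about 28000 nM in this assay, within a range from 9000 nM to 90000 nM.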

Compound 4, half-maximal inhibitory concentration: 21700 nM
For compound 4 the middle estimate is 1.3-fold (0.11 log units) above the measured one; measured number inside the range.
By their numbers in this assay, from the lowest: compound 3; then compound 2; then compounds 1 and 4 (each within the scatter of the next).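

In this assay, within the data shown here, the swap of (cyclohexylmethyl)sulfanyl for hydrogen on this aromatic carbon amounts to a 1.7-fold higher number from compound 1 to compound 4 (0.24 log units; within the scatter), the first comparison in the set that isolates a single place. Within this pair, the whole arm, with its sulfur and its six-membered non-aromatic ring, can therefore be removed from the carbon between the two ring nitrogen atoms without a shift that rises above the usual scatter, so the arm on compound 1 makes no readable contribution to its number. Nothing in the available data offers an explanation for this result.

On these data alone, it remains open whether a smaller methylsulfanyl group, an amine or a carboxylic acid on the same carbon would leave the number in the same place, and whether this holds with another group in place of the phenyl on the other side of the core. As far as these compounds go, compound 2 (5620 nM) and compound 3 (960 nM) differ from compound 1 in more than one place, so it also remains open whether their sulfanyl arm matters to their numbers.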